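Shortening the chain and adding a hydroxyl on the piperidine

This account rests on a few compounds, and the source may have more. Where it says the series, first, only, none or still open, it means among the compounds named here.

For the measured compounds named here, compound 1 `O=C1c2c[n+]([O-])c3ccccc3c2C(=O)c2c1c1ccccc1n2CCCCN1CCCCC1` is one of two compounds measured in a functional assay on A549 cells (Homo sapiens) for cytotoxicity, read by MTT assay, with a stated time of 72 h (a higher number here means a weaker inhibitor, a lower number a stronger inhibitor), where compound 1 gives 150 nM and stands as the lowest of the two numbers. The other is compound 2 `O=C1c2c[n+]([O-])c3ccccc3c2C(=O)c2c1c1ccccc1n2Cc1cn([C@H]2C[C@H](O)[C@@H](CO)O2)nn1`, which in this assay gives 350 nM, a higher number that lies beyond the usual scatter. Compound 3 `O=C1c2c[n+]([O-])c3ccccc3c2C(=O)c2c1c1ccccc1n2CCCN1CCC(O)CC1` has not yet been measured; it shares the core of compound 1 and differs from it in one place: 4-hydroxypiperidin-1-yl in place of (piperidin-1-yl)methyl on a saturated chain carbon, three bonds along the chain from an aromatic nitrogen. Going by the values given here, no measured pair shows this change, so its effect is unknown. The expectation for compound 3 is a modest step, most likely none beyond the scatter or a slight weakening, a 1.5-fold higher number from compound 1 to compound 3 (0.17 log units; within the scatter), because compound 1 gives 150 nM and the change keeps the same ring size. Compound 3 is therefore estimated at 220 nM, with a range from 90 nM to 550 nM.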

Compound 3, half-maximal inhibitory concentration: 350 nM
The estimate for compound 3 lay 1.6-fold (0.20 log units) below the measured number; measured number inside the range.
By their numbers in this assay, from the lowest: compound 1; then compounds 2 and 3 (each within the scatter of the next).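

In this assay, replacing the 4-(piperidin-1-yl)butyl group with 3-(4-hydroxypiperidin-1-yl)propyl gives a 2.3-fold higher number from compound 1 to compound 3 (0.37 log units; beyond the scatter), so this side chain is not indifferent to change, though the step is modest. The swap does two things at once, shortening the chain and adding a hydroxyl with its hydrogen-bond donor, and together they weaken the read-out rather than strengthen it. Nothing shown here explains the step.

What stays open is which of the two edits accounts for the loss, since the step reflects both together. The 3-(piperidin-1-yl)propyl group would isolate the shorter chain and the 4-(4-hydroxypiperidin-1-yl)butyl group would isolate the hydroxyl, so each would separate one edit from the other.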